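The source may hold more compounds than are shown below. What is called first, only, known or untested is meant among the compounds shown, and "the series" means these compounds.

Compound 1 `N#Cc1cccc(-c2cnc(C(=O)CCCCCCc3ccccc3)o2)c1`: 15 nM
Compound 2 `O=C(CCCCCCc1ccccc1)c1ncc(-c2ccc([N+](=O)[O-])cc2)o1`: 50 nM
Compound 3 `O=C(CCCCCCc1ccccc1)c1ncc(-c2ccncn2)o1`: 2.3 nM
Compound 4 `O=C(CCCCCCc1ccccc1)c1ncc(C(=O)N2CCOCC2)o1`: not yet measured

In an assay (Rattus norvegicus) for inhibition of Fatty-acid amide hydrolase 1 (Homo sapiens) (a lower number here means a stronger inhibitor, a higher number a weaker inhibitor), compound 3 gives 2.3 nM, the lowest of the three numbers, and both of its steps to the other compounds lie beyond the scatter: a 6.5-fold lower number from compound 1 to compound 3 (0.81 log units; beyond the scatter), and a 22-fold lower number from compound 2 to compound 3 (1.34 log units; beyond the scatter). Between the two phenyl-bearing compounds the gap was smaller: a 3.3-fold higher number from compound 1 to compound 2 (0.52 log units; beyond the scatter). Compound 3 is therefore the strongest inhibitor among the three measured.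

Compound 4 is made from compound 3 by one change: (morpholin-4-yl)carbonyl in place of pyrimidin-4-yl on an aromatic carbon. The two measured steps that lead into compound 3 each exchanged one six-membered aromatic ring for another on the same carbon of the shared core, and each gave a modest shift. For the measured compounds named here, the change to compound 4 is different in kind, as the group that enters is a non-aromatic ring joined through a carbonyl; no measured step covers such an exchange. In compound 4 the group that gave compound 3 its low number is removed, so a rise in this assay is expected, of modest size but with wide uncertainty. The estimated step is a 13-fold higher number from compound 3 to compound 4 (1.12 log units; beyond the scatter). For compound 4 the estimate is 30 nM, with a range from 8 nM to 150 nM.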

Compound 4, inhibition constant: 24 nM
Beside the measured number, compound 4's estimate is 1.3-fold (0.10 log units) above it; the range from low to high includes it.
By their numbers in this assay, from the lowest: compound 3; then compounds 1 and 4 (each within the scatter of the next); then compound 2.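

On the aromatic carbon next to the ring oxygen, compounds 1, 2 and 3 all carry a six-membered aromatic ring, and compound 4 shows that in this assay a non-aromatic ring joined through a carbonyl is also accepted there, though at a clear cost against pyrimidin-4-yl: a 10-fold higher number from compound 3 to compound 4 (1.02 log units; beyond the scatter). The same group compares well with the two phenyl groups, giving a 2.1-fold lower number from compound 2 to compound 4 (0.32 log units; beyond the scatter) against 4-nitrophenyl and a 1.6-fold higher number from compound 1 to compound 4 (0.20 log units; within the scatter) against 3-cyanophenyl, so among these four compounds an aromatic ring at this place is not required for a number in this range, and only pyrimidin-4-yl stands clearly apart. No measurement at hand gives a reason for these differences.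

The change to compound 4 swaps the ring and inserts a carbonyl in one move, so the compounds shown cannot say which of the two matters more for the step. A carboxylic acid, a methyl ester or a dimethylamino amide at this place would help separate the two, and a pyridin-2-yl ring would test how much the second ring nitrogen of pyrimidin-4-yl contributes.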